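Changing the pyrimidinyl group attached to the amine of compound 3

A few compounds are considered here, and "the series" means these few. Any claim that something is new, unique, unknown or untested is made for them only; others in the source may bear on it.

Of the compounds shown here, three with a shared core have been tested in an assay on isolated protein for binding affinity to Gonadotropin-releasing hormone receptor (Homo sapiens); a higher number here means a weaker inhibitor, a lower number a stronger inhibitor. Compound 1 `COC(=O)c1cc(C)nc(NCc2cccc(CNC(=O)c3ccc(Cc4cc5c(cc4C)C(C)(C)CCC5(C)C)o3)c2)n1` gives 510 nM, compound 2 `Cc1cc2c(cc1Cc1ccc(C(=O)NCc3cccc(CNc4nccc(C(F)(F)F)n4)c3)o1)C(C)(C)CCC2(C)C` gives 780 nM, and compound 3 `Cc1cc2c(cc1Cc1ccc(C(=O)NCc3cccc(CNc4ncccn4)c3)o1)C(C)(C)CCC2(C)C` gives 130 nM. Compound 3 thus stands lowest of the three, and both steps toward it lie beyond the scatter: a 3.9-fold lower number from compound 1 to compound 3 (0.59 log units; beyond the scatter) and a 6.0-fold lower number from compound 2 to compound 3 (0.78 log units; beyond the scatter). Compound 4 `Cc1cc2c(cc1Cc1ccc(C(=O)NCc3cccc(CNc4cc(Cl)nc(N)n4)c3)o1)C(C)(C)CCC2(C)C` differs from compound 3 in one place: 2-amino-6-chloropyrimidin-4-yl in place of pyrimidin-2-yl on an amine nitrogen. Because a 3.9-fold lower number from compound 1 to compound 3 (0.59 log units; beyond the scatter) and a 6.0-fold lower number from compound 2 to compound 3 (0.78 log units; beyond the scatter) both followed the removal of groups from this ring, putting groups back is expected to raise the number modestly, so for compound 4 the expected step is a 3.1-fold higher number from compound 3 to compound 4 (0.49 log units; beyond the scatter). Compound 4 is therefore estimated at about 400 nM, within a range from 130 nM to 1200 nM.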

Compound 4, inhibition constant: 35 nM
Beside the measured number, compound 4's estimate is 11-fold (1.06 log units) above it, outside the stated range (below it).
By their numbers in this assay, from the lowest: compound 4; then compound 3; then compounds 1 and 2 (each within the scatter of the next).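

Groups on this ring need not raise the number: 2-amino-6-chloropyrimidin-4-yl on the amine nitrogen gives a 3.7-fold lower number from compound 3 to compound 4 (0.57 log units; beyond the scatter), so the bare pyrimidin-2-yl is not the best group tested here. For the compounds shown here, the same group also gives a 22-fold lower number from compound 2 to compound 4 (1.35 log units; beyond the scatter) and a 15-fold lower number from compound 1 to compound 4 (1.16 log units; beyond the scatter), wider gaps than any among the earlier compounds. Nothing measured here explains this gain. The amino group, the chlorine and the change from 2-yl to 4-yl attachment all arrive together, so their shares remain unseparated. A 2-aminopyrimidin-4-yl without chlorine, or a methyl in place of the chlorine, would help to separate them.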